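The source may hold more compounds than are shown below. What is called first, only, known or untested is meant among the compounds shown, and "the series" means these compounds.

Series notes. Compound 1 `CCN1CCN(CC(=O)Nc2ccc(-c3nc(-c4ccccc4)c(-c4ccccc4)n3C)cc2)CC1` and compound 2 `CN(C)/C=C/N1CCN(CC(=O)Nc2ccc(-c3nc(-c4ccccc4)c(-c4ccccc4)n3C)cc2)CC1` share one core and differ only in the group on an amine nitrogen in a ring. In a functional assay on HT-29 cells (Homo sapiens) for cytotoxicity, read by MTT assay, with a stated time of 24 h, tested at 80 ug/mL (on this read-out higher numbers stand for a stronger effect at the one concentration tested and lower numbers for a weaker effect), compound 1 gives 51.2%, and compound 2 gives 45.4%. The step of a number 5.8 percentage points lower from compound 1 to compound 2 (within the scatter) stays within the scatter. Compound 2 therefore stands with the lower of the two numbers, yet not apart from compound 1.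

Compound 3 `Cn1c(-c2ccc(NC(=O)CN3CCN(c4ccccc4)CC3)cc2)nc(-c2ccccc2)c1-c1ccccc1` is the next member: phenyl in place of 2-(dimethylamino)ethenyl on an amine nitrogen in a ring. Among the compounds with values here, the only measured step that bears on this change is a number 5.8 percentage points lower from compound 1 to compound 2 (within the scatter), where one small group replaced another on the same nitrogen without moving the number beyond the scatter. No phenyl on that nitrogen has been measured, so the data give no direction. On that basis no step beyond the scatter is expected in this assay, and the expected change is a number 0.6 percentage points higher from compound 2 to compound 3 (within the scatter). Compound 3 is estimated at 46%, with a range from 34% to 58%.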

Compound 3, a percentage reported as activity, at one concentration (the size of the read-out at that concentration, not a potency): 63.7%
The estimate for compound 3 lay 17.7 percentage points below the measured number; the whole stated range lies below it.
By their numbers in this assay, from the lowest: compounds 2 and 1 (each within the scatter of the next); then compound 3.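

At the amine nitrogen in the ring, the group on that atom can move the number in this assay: phenyl in place of 2-(dimethylamino)ethenyl gives (a number 18.3 percentage points higher from compound 2 to compound 3 (beyond the scatter)) and phenyl in place of ethyl gives (a number 12.5 percentage points higher from compound 1 to compound 3 (beyond the scatter)), and both steps lie beyond the scatter. Among these three compounds, the one group with an aromatic ring stands apart from the two groups without a ring, which remain within the scatter of each other. No measurement at hand accounts for the rise.

The compounds shown leave open whether the rise belongs to phenyl itself or would also appear with a cyclohexyl ring, a benzyl group or a pyridine ring on the same nitrogen. With one concentration per compound, they show a stronger effect for compound 3 at that concentration only and leave open whether the order would hold at any other concentration.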